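A Small Swap from Compound 3 to Compound 4

The source may report more compounds than this note shows. Statements on the series, on what has been measured and on what is new or still open speak of the compounds shown alone.

Values in a functional assay on HUVEC cells (Homo sapiens), read by scintillation counting and thymidine incorporation, with a stated time of 24 h; on this read-out lower numbers stand for stronger inhibition and higher numbers for weaker inhibition:
- compound 1 `CCC(C)n1ncn(-c2ccc(N3CCN(c4ccc(OC[C@@H]5CO[C@@](Cn6ccnc6C)(c6ccc(Cl)cc6Cl)O5)cc4)CC3)cc2)c1=O`: 173 nM
- compound 2 `CCc1nccn1C[C@@]1(c2ccc(Cl)cc2Cl)OC[C@@H](COc2ccc(N3CCN(c4ccc(-n5cnn(C(C)CC)c5=O)cc4)CC3)cc2)O1`: 224 nM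
- compound 3 `CCC(C)n1ncn(-c2ccc(N3CCN(c4ccc(OC[C@@H]5CO[C@@](Cn6ccnc6-c6ccccc6)(c6ccc(Cl)cc6Cl)O5)cc4)CC3)cc2)c1=O`: 136 nM

Compound 3, at 136 nM, lies within the usual scatter of both other compounds, so the three cannot be ranked. The next compound to be tested is compound 4 `CCC(C)n1ncn(-c2ccc(N3CCN(c4ccc(OC[C@@H]5CO[C@@](Cn6c(C)cnc6C)(c6ccc(Cl)cc6Cl)O5)cc4)CC3)cc2)c1=O`. It differs from compound 3 in one place: 2,5-dimethyl-1H-imidazol-1-yl in place of 2-phenyl-1H-imidazol-1-yl on a saturated chain carbon bound to a saturated ring carbon. In words, 2,5-dimethyl-1H-imidazol-1-yl stands in place of 2-phenyl-1H-imidazol-1-yl on a saturated chain carbon bound to a saturated ring carbon.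

Within the data shown here, three measured steps bear on this change. Phenyl in place of methyl gave a 1.3-fold lower number from compound 1 to compound 3 (0.10 log units; within the scatter). Phenyl in place of ethyl gave a 1.6-fold lower number from compound 2 to compound 3 (0.22 log units; within the scatter). Methyl in place of hydrogen on the chain gave a 1.3-fold higher number from compound 1 to compound 2 (0.11 log units; within the scatter). None of these steps leaves the scatter, so no step beyond the scatter is expected in this assay. Among the measured compounds shown here, no measured compound carries the 2,5-dimethyl-1H-imidazol-1-yl group, which leaves some uncertainty.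

The expected step is a 1.3-fold higher number from compound 3 to compound 4 (0.10 log units; within the scatter). For compound 4 the estimated value is 170 nM, with an expected range from 85 nM to 340 nM.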

Compound 4, half-maximal inhibitory concentration: 765 nM
Beside the measured number, compound 4's estimate is 4.5-fold (0.65 log units) below it, and the stated range ends below it.
By their numbers in this assay, from the lowest: compounds 3, 1 and 2 (each within the scatter of the next); then compound 4.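

In this assay, swaps among the 2-methyl, 2-ethyl and 2-phenyl groups on this saturated chain carbon had moved the number only within the scatter, yet one added methyl on an aromatic carbon gives a 4.4-fold higher number from compound 1 to compound 4 (0.65 log units; beyond the scatter). The other two comparisons point the same way, with a 5.6-fold higher number from compound 3 to compound 4 (0.75 log units; beyond the scatter) and a 3.4-fold higher number from compound 2 to compound 4 (0.53 log units; beyond the scatter), so the 2,5-dimethyl-1H-imidazol-1-yl group separates compound 4 from all three earlier compounds. Nothing available explains why this one methyl counts for so much.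

The compounds shown leave open whether the same added methyl would raise the number as far on the 2-ethyl or 2-phenyl imidazol-1-yl groups. They also leave open whether a chlorine, a methoxy group or a longer chain on that aromatic carbon would give a similar step.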